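Benzyl to phenyl on the amine of the shared core

The compounds below may be only part of what the source reports. "The series", "measured", "known", "first", "only" and "open" are said of these compounds alone.

Of the compounds shown here, two have been tested in a functional assay on ECa-109 cells for inhibition, with ECa-109 cell line (Homo sapiens) as the target, read by sulforhodamine B assay; on this read-out lower numbers stand for stronger inhibition and higher numbers for weaker inhibition. Compound 1 `CCCc1ccc(NC2=CC(=O)c3c(nc4n3[C@H]3OC[C@@H](O)[C@H]3OC4)C2=O)cc1` carries a propyl-substituted anilino group on the shared core; in this assay compound 1 gives only a limit of the assay, > 4000 nM, and no number. Compound 2 `O=C1C=C(NCc2ccccc2)C(=O)c2c1nc1n2[C@H]2OC[C@@H](O)[C@H]2OC1` carries a benzylamino group on the same core; in this assay compound 2 likewise gives only a limit, > 8000 nM, and no number. Among the compounds with values here, compound 2 therefore stands at a limit, as does the one other value shown (the limit of > 4000 nM in this assay, at which 1 of the 2 values shown sits, (the limit of > 8000 nM in this assay, at which 1 of the 2 values shown sits)), so no step between measured compounds can be sized and no direction is known.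

Compound 3 `O=C1C=C(Nc2ccccc2)C(=O)c2c1nc1n2[C@H]2OC[C@@H](O)[C@H]2OC1` is the next member to be measured. It differs from compound 2 in one place: phenyl in place of benzyl on an amine nitrogen. The anilino arrangement that results is also present, with an added propyl, in compound 1, whose value is a limit. No step beyond the usual scatter is expected for a number no higher from compound 2 to compound 3 (the limit leaves the size open). In this assay compound 3 is estimated to give 8000 nM, with a range from 2000 nM to 30000 nM, and most likely again only a limit.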

Compound 3, half-maximal inhibitory concentration: 4970 nM
Compound 3: middle estimate off by 1.6-fold (0.21 log units), on the high side, and the stated range covers the measured number.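

Within the data shown here, compound 3 is the first member of the series to give a number rather than a limit, 4970 nM in this assay, so a phenyl on this amine nitrogen yields a readable value on the shared core. Replacing benzyl with phenyl gives an at least 1.6-fold lower number from compound 2 to compound 3 (0.20 log units; that floor lies within the scatter), which fixes only a floor on the step, so it cannot yet be said whether the change has a real effect or how large that effect is. Going by these compounds, the benzylamino member remains open-ended, and compound 2 is still only a limit: the limit of > 8000 nM in this assay, at which 1 of the 3 values shown sits.

On these data alone, compound 1, the anilino member with an added propyl, is also only a limit, > 4000 nM, so the step between it and compound 3 cannot be read, and the effect of the propyl group remains unknown. Also open, as far as these compounds go, is how this assay would respond to a methoxy group, a carboxylic acid or a dimethylamino group on the phenyl ring, or to a longer chain such as phenethyl on the amine nitrogen.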